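The compounds below may be only part of what the source reports. "The series", "measured", "known", "first", "only" and "open" are said of these compounds alone.

Of the compounds shown here, three built on one shared core have been tested in an ADME assay on BHK-21 cells (Mesocricetus auratus) for cytotoxicity, with a stated time of 3 days; on this read-out lower numbers stand for higher toxicity in this test and higher numbers for lower toxicity in this test. Compound 1 `CC(Sc1nnc(-c2ccncc2)s1)C(=O)Nc1ccccc1Cl` carries a 2-chlorophenyl group on its amide-type nitrogen, compound 2 `CC(Sc1nnc(-c2ccncc2)s1)C(=O)Nc1ccccc1` a phenyl group, and compound 3 `CC(Sc1nnc(-c2ccncc2)s1)C(=O)NCc1ccccc1` a benzyl group. In this assay compound 1 gives > 50000 nM, which is a limit of the assay rather than a number. Compound 2 likewise gives > 50000 nM, again a limit. Compound 3 gives > 50000 nM, also a limit. Compound 3 therefore stands exactly where its two companions stand, namely at the limit of > 50000 nM in this assay, at which 3 of the 3 values shown sit. Because all three values are limits, none of the steps between them can be sized: a step that the two limits leave unreadable from compound 1 to compound 2, a step that the two limits leave unreadable from compound 1 to compound 3 and a step that the two limits leave unreadable from compound 2 to compound 3 all remain unreadable.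

Compound 4 `CC(Sc1nnc(-c2ccncc2)s1)C(=O)Nc1ccc(Cl)cc1` differs from compound 3 in one place: 4-chlorophenyl in place of benzyl on an amide-type nitrogen. The measured steps that touch the same kind of change, the swap of benzyl for phenyl and the presence of a chloro substituent, are exactly the unreadable ones, so they give no direction and no size. The expected step from compound 3 to compound 4 is therefore a step that the limit leaves unreadable from compound 3 to compound 4, nothing beyond the scatter. Compound 4 is estimated at 60000 nM, with a range from 25000 nM to 150000 nM, most likely reported as a limit once more.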

Compound 4, half-maximal cytotoxic concentration: > 50000 nM
Compound 4 ended at the assay's limit; the forecaster's own chance of this, stated with the estimate: 80%; the middle value does not contradict the limit.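

In this assay compound 4 gives > 50000 nM, which is a limit of the assay and not a number. Its steps to compound 1, compound 2 and compound 3 therefore cannot be read: the limit of > 50000 nM in this assay, at which 4 of the 4 values shown sit. The compounds shown leave open what concentration would harm these cells for any of the four, and whether changing the group on the amide-type nitrogen alters it.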